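Methoxy in place of methyl: carrying one step to a second pair

This account rests on a few compounds, and the source may have more. Where it says the series, first, only, none or still open, it means among the compounds named here.

Compound 1 `Cc1ccc(-c2nnc(NC(=O)c3ccccc3O)s2)cc1` gives 1970 nM in a functional assay on B16-F10 cells (Mus musculus) for antiproliferative activity, read by MTT assay, with a stated time of 48 h; on this read-out higher numbers stand for weaker inhibition and lower numbers for stronger inhibition. Compound 2 `COc1ccc(-c2nnc(NC(=O)c3ccccc3O)s2)cc1` carries methoxy in place of methyl on an aromatic carbon and gives 1390 nM in this assay; the step is a 1.4-fold lower number from compound 1 to compound 2 (0.15 log units; within the scatter). Compound 3 `Cc1ccc(-c2nnc(NC(=O)c3ccccc3)s2)cc1` differs from compound 1 in its core by hydrogen in place of hydroxy on an aromatic carbon; in this assay compound 3 gives 3520 nM, with a 1.8-fold higher number from compound 1 to compound 3 (0.25 log units; within the scatter). Compound 4 `COc1ccc(-c2nnc(NC(=O)c3ccccc3)s2)cc1` has not been measured. It stands to compound 3 as compound 2 stands to compound 1, through (methoxy in place of methyl on an aromatic carbon), the same change at the same place, seen once so far among the measured compounds. For compound 4 a step of a 1.4-fold lower number from compound 3 to compound 4 (0.15 log units; within the scatter) is expected in this assay, resting on the pair compound 1 and compound 2 because a 1.4-fold lower number from compound 1 to compound 2 (0.15 log units; within the scatter). Compound 4 is estimated at 2500 nM, between 1200 nM and 5500 nM.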

Compound 4, half-maximal inhibitory concentration: 1580 nM
Estimate against measurement, compound 4: 1.6-fold (0.20 log units) above; the range from low to high includes it.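

In this assay, methoxy in place of methyl carries to the core lacking the hydroxy, with a 2.2-fold lower number from compound 3 to compound 4 (0.35 log units; beyond the scatter), and agrees with the earlier step: the same change on two cores in this assay, a 1.4-fold lower number (0.15 log units; within the scatter) from compound 1 to compound 2 and a 2.2-fold lower number (0.35 log units; beyond the scatter) from compound 3 to compound 4, 1.6-fold (0.20 log units) apart, within the scatter of two such steps. Hydrogen in place of hydroxy, read on the methoxy compounds, gives a 1.1-fold higher number from compound 2 to compound 4 (0.06 log units; within the scatter), and this also agrees with the earlier step: the same change on two cores in this assay, a 1.8-fold higher number (0.25 log units; within the scatter) from compound 1 to compound 3 and a 1.1-fold higher number (0.06 log units; within the scatter) from compound 2 to compound 4, 1.6-fold (0.20 log units) apart, within the scatter of two such steps. Within the data shown here, each change has been seen on only two cores, so this supports carrying them within these four compounds but fixes no general step size, and only the step from methyl to methoxy on the core lacking the hydroxy lies beyond the scatter.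

As far as these compounds go, whether ethoxy, a longer chain or an amine at the same place would follow methoxy remains open. So does whether an amine or a carboxylic acid in place of the hydroxy would leave these steps unchanged.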